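Replacing the fluorophenyl group of compound 2

A few compounds are considered here, and "the series" means these few. Any claim that something is new, unique, unknown or untested is made for them only; others in the source may bear on it.

Measured so far in a functional assay on COLO 205 cells (Homo sapiens) for cytotoxicity; on this read-out lower numbers stand for stronger inhibition and higher numbers for weaker inhibition:
- compound 1 `COc1ccc(-n2nc(Nc3cc(C)[nH]n3)c3ccccc3c2=O)cc1`: 3700 nM
- compound 2 `Cc1cc(Nc2nn(-c3ccc(F)cc3)c(=O)c3ccccc23)n[nH]1`: 1600 nM
- compound 3 `Cc1ccc(-n2nc(Nc3cc[nH]n3)c3ccccc3c2=O)cc1`: "not determined" (no result reported)

Of the two compounds with a number, compound 2 stands lowest at 1600 nM, which makes it the stronger inhibitor of the pair in this assay. Compound 4 `Cc1cc(Nc2nn(Cc3csc(C)n3)c(=O)c3ccccc23)n[nH]1` keeps the shared core but carries (2-methyl-1,3-thiazol-4-yl)methyl in place of 4-fluorophenyl on an aromatic nitrogen. Among the compounds with values here, only one measured step bears on this change: a 2.3-fold lower number from compound 1 to compound 2 (0.36 log units; beyond the scatter). That modest step swapped methoxy for fluoro on an aromatic carbon and kept the ring itself, whereas compound 4 loses the whole 4-fluorophenyl group. Within the data shown here, it is therefore a weak guide, and no measured pair shows such a replacement. A modest move towards weaker inhibition seems most likely, with a wide margin in either direction. The expected step is a 1.9-fold higher number from compound 2 to compound 4 (0.27 log units; within the scatter). The estimate for compound 4 is 3000 nM, with an expected range from 800 nM to 11000 nM.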

Compound 4, half-maximal inhibitory concentration: > 30000 nM
Compound 4 gave a limit, no number; the forecaster's own chance of this, stated with the estimate: 10%; at least 10-fold (1.00 log units) between middle value and limit.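

In this assay compound 4 gave a limit rather than a number: the limit of > 30000 nM in this assay, at which 1 of the 4 values shown sits.

Putting (2-methyl-1,3-thiazol-4-yl)methyl in place of 4-fluorophenyl gives an at least 18-fold higher number from compound 2 to compound 4 (1.27 log units; beyond the scatter), and putting it in place of 4-methoxyphenyl gives an at least 8.1-fold higher number from compound 1 to compound 4 (0.90 log units; beyond the scatter). Both steps are far larger than the earlier change of methoxy to fluoro, so the group on this aromatic nitrogen can move the read-out much more than that swap suggested.

This single change replaces the six-membered ring with a five-membered ring and also sets a carbon link between ring and nitrogen, and the compounds shown do not separate these two effects. On these data alone, a plain benzyl group on the same nitrogen would keep the carbon link with a six-membered ring of carbon only, and its effect remains open.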